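Bromo Added to the Aryl Thiourea of Compound 2

The compounds below may be only part of what the source reports. "The series", "measured", "known", "first", "only" and "open" are said of these compounds alone.

Of the compounds shown here, two of one thiourea family have been tested in an ADME assay on Huh-7 cells (Homo sapiens) for cytotoxicity; a higher number here means that more compound is tolerated, a lower number that less compound is tolerated. Compound 1 `NC(=S)Nc1cccc(OCCCCCNC(=S)Nc2ccc(Cl)cc2)c1` carries a chloro group on one of its aryl thioureas and a shorter linker. In this assay compound 1 reaches only a limit of the assay, > 50000 nM. Compound 2 `NC(=S)Nc1cccc(OCCCCCCCCNC(=S)Nc2ccccc2)c1` has a longer linker and a plain phenyl thiourea. In this assay compound 2 likewise gives a limit and not a number, > 50000 nM. Compound 2 thus stands where everything measured so far stands, because of the limit of > 50000 nM in this assay, at which 2 of the 2 values shown sit.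

Compound 3 `NC(=S)Nc1cccc(OCCCCCCCCNC(=S)Nc2cccc(Br)c2)c1` differs from compound 2 in one place: bromo in place of hydrogen on an aromatic carbon, on the phenyl of the second thiourea. Among the measured compounds shown here, no measured pair shows a step of this kind, so its size cannot be read from the data. The step from compound 2 to compound 3 is expected to be a step that the limit leaves unreadable from compound 2 to compound 3, none beyond the scatter. Compound 3 is expected to give 60000 nM, within 25000 nM to 150000 nM, and most likely again only as a limit.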

Compound 3, half-maximal cytotoxic concentration: 20000 nM
Compound 3: middle estimate off by 3.0-fold (0.48 log units), on the high side; the measured number lies below the stated range.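

In this assay, bromo in place of hydrogen on the phenyl of the second thiourea gives an at least 2.5-fold lower number from compound 2 to compound 3 (0.39 log units; beyond the scatter). Compound 3 is thus the only compound shown that yields a number and not a limit, and it shows that this place on the ring, meta to a large group, does not leave the read-out untouched when hydrogen gives way to bromo. From the compounds shown here alone, the size of the step is known from one side only, and its full extent stays unknown, because the starting value is not a number: the limit of > 50000 nM in this assay, at which 2 of the 3 values shown sit.

Whether the lower number belongs to bromo in particular remains open, since the compounds shown do not include a chloro, fluoro, methyl or methoxy group at this same place on the octyl-linked compound. Nor can any step be read to or from compound 1, which differs from the others in more than one place, so these compounds do not show how the length of the chain or a halogen on the ring of a shorter-chain compound bears on this assay.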